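Aryl variation on the oxadiazole arm of the shared core

A few compounds are considered here, and "the series" means these few. Any claim that something is new, unique, unknown or untested is made for them only; others in the source may bear on it.

Compound 1 `CS(=O)(=O)c1ccc(-c2cnc3[nH]cc(-c4nnc(-c5ccccc5)o4)c(=O)c3c2)cc1` carries a phenyl on the five-membered ring; in a functional assay on HCT-116 cells (Homo sapiens) for inhibition, read by MTT assay, with a stated time of 24 h, tested at 10 uM (on this read-out lower numbers stand for less inhibition of growth and higher numbers for more inhibition of growth at the one concentration tested), compound 1 gives 15.7%. Compound 2 `CS(=O)(=O)c1ccc(-c2cnc3[nH]cc(-c4nnc(-c5ccccn5)o4)c(=O)c3c2)cc1` carries pyridin-2-yl in the same position, and in this assay compound 2 gives 16.2%. Going by the values given here, the only step so far, a number 0.5 percentage points higher from compound 1 to compound 2 (within the scatter), is small. On the numbers shown compound 2 sits at the upper of the two values, with compound 1 the nearest, and the two lie within the scatter of each other. Compound 3 `CS(=O)(=O)c1ccc(-c2cnc3[nH]cc(-c4nnc(-c5ccc(Cl)cc5)o4)c(=O)c3c2)cc1` brings the change (4-chlorophenyl in place of pyridin-2-yl on an aromatic carbon). Among the compounds with values here, the one step that bears on this position, from phenyl to a six-membered hetero aromatic ring, did not move this assay beyond the scatter, so no step beyond the scatter is expected here either, a number 0.8 percentage points higher from compound 2 to compound 3 (within the scatter). Compound 3 is therefore estimated at 17% in this assay, with a range from 5% to 30%.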

Compound 3, percent growth inhibition at one concentration: 17%
Estimate against measurement, compound 3: no gap at the digits printed; the range from low to high includes it.
By their numbers in this assay, from the lowest: compounds 1, 2 and 3 (each within the scatter of the next).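

In this assay the swap of pyridin-2-yl for 4-chlorophenyl gives a number 0.8 percentage points higher from compound 2 to compound 3 (within the scatter) and so adds a second aromatic ring type to the comparison at this position on the five-membered ring. Chloro in place of hydrogen on an aromatic carbon gives a number 1.3 percentage points higher from compound 1 to compound 3 (within the scatter) and is the first substituent on the aryl ring itself to be read here, so the added chlorine does not separate compound 3 from compound 1 in this measurement. All three aryl groups thus lie within the scatter of one another, and no measurement on hand offers an account of these small steps.

As far as these compounds go, whether an amine or a carboxylic acid on this aryl ring would move the read-out beyond the scatter remains open. Also open, from the compounds shown here alone, is whether a longer alkyl chain in place of the aryl ring would do so.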